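Methoxy Added to a Core That Shows Only Limits

The source may report more compounds than this note shows. Statements on the series, on what has been measured and on what is new or still open speak of the compounds shown alone.

Compound 1 `Cn1c(-c2ccccc2)nnc1[S+](C)[O-]` is known only as a bound: in a functional assay on the whole organism for antagonist activity, with Mus musculus as the target, in the maximal electroshock model (on this read-out higher numbers stand for an effect only at larger amounts of compound and lower numbers for an effect already at smaller amounts), compound 1 gives > 100 mg/kg, a limit of the assay rather than a number. Compound 2 `CC[S+]([O-])c1nnc(-c2ccccc2)n1C` is also only bounded; in this assay compound 2 gives > 200 mg/kg, again a limit. Among the compounds with values here, the single measured step, a step that the two limits leave unreadable from compound 1 to compound 2, thus has no readable size. Compound 3 `COc1ccc(-c2nnc([S+](C)[O-])n2C)cc1` differs from compound 1 by methoxy in place of hydrogen on an aromatic carbon. Within the data shown here, no measured step bears on this change, and the limit of > 100 mg/kg in this assay, at which 1 of the 2 values shown sits, together with the limit of > 200 mg/kg in this assay, at which 1 of the 2 values shown sits, offers no scale, so the step that the limit leaves unreadable from compound 1 to compound 3 is expected to stay unreadable, most likely as another limit. Compound 3 is estimated at 150 mg/kg, between 40 mg/kg and 500 mg/kg.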

Compound 3, dose for half-maximal effect: > 100 mg/kg
Compound 3 ended at the assay's limit; the forecaster's own chance of this, stated with the estimate: 80%; the middle value does not contradict the limit.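

Within the data shown here, compound 1 and compound 3 are both known only as limits of the assay, so no step between them can be read. The compounds shown leave open whether methoxy in place of hydrogen on an aromatic carbon changes the result at all.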